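Ester to Acid-Bearing Amide on a Shared Core

The source may report more compounds than this note shows. Statements on the series, on what has been measured and on what is new or still open speak of the compounds shown alone.

Three compounds share one core and differ only in the group on the carbonyl carbon of the chain. Compound 1 `O=C(O)[C@@H]1CCCN1C(=O)/C=C/c1ccncc1-c1ccc2ccccc2c1` carries an amide ending in a carboxylic acid; in an assay on a protein complex for inhibition of CDK8/Cyclin C (Homo sapiens), with a stated time of 1 h (on this read-out lower numbers stand for stronger inhibition and higher numbers for weaker inhibition), compound 1 gives "not determined" (no result reported), so no number is available for it. Compound 2 `CCOC(=O)/C=C/c1ccncc1-c1ccc2ccccc2c1` is an ethyl ester, and in this assay compound 2 gives 53.3 nM. Compound 3 `COC(=O)/C=C/c1ccncc1-c1ccc2ccccc2c1` is the methyl ester, and in this assay compound 3 gives 40.6 nM; the step of a 1.3-fold lower number from compound 2 to compound 3 (0.12 log units; within the scatter) is within the scatter, so the two esters cannot be told apart on these numbers. Compound 4 `O=C(O)CCNC(=O)/C=C/c1ccncc1-c1ccc2ccccc2c1` introduces ((2-carboxyethyl)amino in place of methoxy on a carbonyl carbon). Within the data shown here, the only measured step, from compound 2 to compound 3, swaps one ester alkyl for another and says nothing about replacing the ester with an amide that carries an acid, and compound 1, the closest analogue, has no number. With no guidance from the measured steps, the step of a 2.0-fold higher number from compound 3 to compound 4 (0.29 log units; within the scatter) is estimated to be modest, with a wide range allowed. Compound 4 is therefore expected to give about 80 nM, between 20 nM and 400 nM.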

Compound 4, half-maximal inhibitory concentration: 870 nM
Compound 4: middle estimate off by 11-fold (1.04 log units), on the low side; measured number above the stated range.
By their numbers in this assay, from the lowest: compounds 3 and 2 (each within the scatter of the next); then compound 4.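

The two esters could not be told apart, but the group on this carbonyl carbon is clearly not free to vary. Putting (2-carboxyethyl)amino in place of methoxy gives a 21-fold higher number from compound 3 to compound 4 (1.33 log units; beyond the scatter) in this assay, and putting it in place of ethoxy gives a 16-fold higher number from compound 2 to compound 4 (1.21 log units; beyond the scatter), so this amide ending in a carboxylic acid is much less well tolerated here than either small ester. Nothing measured here explains why the number rises so far.

This single change brings in an amide link, a longer chain and a carboxylic acid together, and the compounds shown cannot say which of these matters. A plain ethylamino group, or the same chain ending in a methyl ester instead of the acid, would help separate those parts.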